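The compounds below may be only part of what the source reports. "The series", "measured", "known", "first", "only" and "open" are said of these compounds alone.

Measured compounds in an assay on CHO-K1 cells for antagonist activity at transient receptor potential cation channel subfamily V member 1 (Homo sapiens), read by FLIPR; on this read-out lower numbers stand for stronger inhibition and higher numbers for weaker inhibition:
compound 1 `CC(C(=O)NCc1cc(C(F)(F)F)nn1-c1cccc(C(F)(F)F)c1)c1ccc2c(c1)CCC2` gives 7.5 nM.
compound 2 `CC(C(=O)NCc1cc(C(F)(F)F)nn1-c1ccc(OC(F)(F)F)cc1)c1ccc2c(c1)CCC2` gives 51.6 nM.

Among the compounds with values here, compound 2 gives the highest of these two numbers; its nearest neighbour is compound 1, and the only measured step runs between them: a 6.9-fold higher number from compound 1 to compound 2 (0.84 log units; beyond the scatter).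

Compound 3 `Cc1ccc(-n2nc(C(F)(F)F)cc2CNC(=O)C(C)c2ccc3c(c2)CCC3)cc1C` has not yet been measured in this assay. It differs from compound 2 in one place: 3,4-dimethylphenyl in place of 4-(trifluoromethoxy)phenyl on an aromatic nitrogen. The group that enters carries no hydrogen-bond acceptor, whereas the group that leaves carried one.

Within the data shown here, only the step from compound 1 to compound 2 bears on this change, since it too swaps the group on an aromatic nitrogen of the same ring; that step was modest, and it shows that a swap at this place can move the number beyond the scatter. Whether 3,4-dimethylphenyl ends up closer to the group of compound 1 or to that of compound 2 is not told by these data. Compound 3 is therefore expected to land between the two measured values, a step of a 2.6-fold lower number from compound 2 to compound 3 (0.41 log units; beyond the scatter), giving an estimate of 20 nM with a range from 5 nM to 90 nM.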

Compound 3, inhibition constant: 11.3 nM
Compound 3: middle estimate off by 1.8-fold (0.25 log units), on the high side; low and high end bracket the measured number.
By their numbers in this assay, from the lowest: compounds 1 and 3 (each within the scatter of the next); then compound 2.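

In this assay, putting 3,4-dimethylphenyl in place of 4-(trifluoromethoxy)phenyl gives a 4.6-fold lower number from compound 2 to compound 3 (0.66 log units; beyond the scatter) and thus shows that the hydrogen-bond acceptor counted in the leaving group is not needed for a low number at this position. The comparison with the other measured group gives a 1.5-fold higher number from compound 1 to compound 3 (0.18 log units; within the scatter) for 3,4-dimethylphenyl in place of 3-(trifluoromethyl)phenyl and thus shows that a group made only of carbon and one that carries fluorine cannot be told apart here, leaving compound 2 alone with the higher number. No measurement at hand accounts for these differences.

The compounds shown do not tell whether both methyl groups of compound 3 are needed, since neither 3-methylphenyl nor 4-methylphenyl appears among them, and they do not separate the effect of the 4-(trifluoromethoxy) group from that of having no group named at the 3 position of the phenyl ring. They also leave open how this position would respond to a phenyl ring bearing an amine or a carboxylic acid.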